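Tetramethoxy to fewer methoxy groups: working notes

The source may hold more compounds than are shown below. What is called first, only, known or untested is meant among the compounds shown, and "the series" means these compounds.

compound 1 `COc1cc(OC)c(OC)cc1/C=C/COC(=O)/C=C/c1ccc(OC)c(OC)c1` gives 58.1 mg/kg
compound 2 `COc1cc(OC)c(OC)cc1/C=C/COC(=O)/C=C/c1cc(OC)c(OC)c(OC)c1OC` gives 30.9 mg/kg

Both numbers come from a functional assay on the whole organism (strain Kunming) with Mus musculus as the target, with a stated time of 0.5 h (a lower number here means that less compound is needed, a higher number that more compound is needed for the effect), and lie within the usual scatter of each other, so compound 2 at 30.9 mg/kg stands level with compound 1 (58.1 mg/kg) on the data so far.

The next compound is compound 3 (`COc1cc(OC)c(OC)cc1/C=C/COC(=O)/C=C/c1ccc(OC)c(OC)c1OC`), which differs from compound 2 at a single place (hydrogen in place of methoxy on an aromatic carbon): hydrogen in place of methoxy on an aromatic carbon. Within the data shown here, no step between measured compounds that differ in one place is available, so this change has no direct precedent in this assay. Compound 3 keeps every methoxy group of compound 1 and lacks one of compound 2, so its structure falls between the two. The closeness of compound 1 (58.1 mg/kg) and compound 2 (30.9 mg/kg) gives no reason to expect a large move. The estimated step is small, toward a higher number and within the scatter (a 1.3-fold higher number from compound 2 to compound 3 (0.11 log units; within the scatter)). The value expected for compound 3 is 40 mg/kg (estimated range 18 mg/kg to 85 mg/kg).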

Compound 3, dose for half-maximal effect: 33.4 mg/kg
Beside the measured number, compound 3's estimate is 1.2-fold (0.08 log units) above it; the measured number falls inside the stated range.
By their numbers in this assay, from the lowest: compounds 2, 3 and 1 (each within the scatter of the next).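

Working notes, methoxy at this position

In this assay, hydrogen in place of methoxy on an aromatic carbon, at the site ortho to a methoxy group and meta to a large group, leaves compound 2 and compound 3 level (a 1.1-fold higher number from compound 2 to compound 3 (0.03 log units; within the scatter)), so the read-out does not depend measurably on this methoxy group. The series now also has a single methoxy step on a different aromatic carbon of the same ring, and it too stays within the scatter (a 1.7-fold lower number from compound 1 to compound 3 (0.24 log units; within the scatter)), so neither single step separates the compounds on its own. No measurement on hand bears on the reason for these results.

Still open, from the compounds shown here alone, is whether this aromatic carbon would stay level with anything other than hydrogen or methoxy, such as a hydroxyl, an amine, fluorine or a longer chain like butoxy. All three compounds also keep the rest of the shared core unchanged, so the role of that remaining structure in this whole-animal read-out cannot be judged from them.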